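Swapping Isopropyl for 3-Bromophenyl on the Amine Nitrogen

This account rests on a few compounds, and the source may have more. Where it says the series, first, only, none or still open, it means among the compounds named here.

Measured compounds:
compound 1, `CCCc1nn(C)c2c(NC(C)C)nc(CCc3cccnc3)nc12`: 514000 nM
compound 2, `CC(C)Nc1nc(/C=C/c2ccccc2)nc2ccsc12`: > 1000000 nM

Of the compounds shown here, two have been measured in a functional assay on L02 cells (Homo sapiens) for inhibition, read by Griess assay, with stated times of 1 h and 24 h; on this read-out lower numbers stand for stronger inhibition and higher numbers for weaker inhibition. Compound 1 gives 514000 nM. For compound 2 the reading is a limit of the assay, > 1000000 nM, so compound 2 stands at the limit of > 1000000 nM in this assay, at which 1 of the 2 values shown sits, and has no number of its own. Compound 3, `Brc1cccc(Nc2nc(/C=C/c3ccccc3)nc3ccsc23)c1`, is not yet measured; it differs from compound 2 in one place: 3-bromophenyl in place of isopropyl on a nitrogen on an aromatic ring. Within the data shown here, no step between measured compounds exists, and compound 1 and compound 2 differ in more than one place, so their values show only that both are weak in this assay. For the change from compound 2 to compound 3, a shift of no more than the scatter, or a slight gain, is expected; the estimated step is an at least 1.2-fold lower number from compound 2 to compound 3 (0.09 log units; that floor lies within the scatter). Compound 3 is therefore expected to give about 800000 nM, between 200000 nM and 3000000 nM, with a real chance that the assay again returns only a limit.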

Compound 3, half-maximal inhibitory concentration: > 1000000 nM
Compound 3 gave a limit, no number (the forecaster's own chance of this, stated with the estimate: 50%); middle value at least 1.2-fold (0.09 log units) away from the limit.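

In this assay, among these compounds, compound 2 and compound 3 each return only a limit, so no step between them can be read: the limit of > 1000000 nM in this assay, at which 2 of the 3 values shown sit. From the compounds shown here alone, how far either compound lies beyond that limit, and whether 3-bromophenyl in place of isopropyl changes inhibition at all, stays open.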